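Adding a Second Methoxy to an Inactive Compound

The compounds below may be only part of what the source reports. "The series", "measured", "known", "first", "only" and "open" are said of these compounds alone.

- Compound 1 `COc1ccc(/C=C/C(=O)/C=C/c2cc3ccccc3nc2Cl)cc1` in a functional assay on NCI-H460 cells (Homo sapiens) for cytotoxicity, read by MTT assay, with a stated time of 48 h; on this read-out higher numbers stand for weaker inhibition and lower numbers for stronger inhibition: > 10000 nM, a limit
- Compound 2 `COc1ccc(/C=C/C(=O)/C=C/c2cc3ccccc3nc2Oc2ccccc2)cc1` in this assay: > 10000 nM, a limit

Compound 2 has no exact number, only the limit > 10000 nM. The picture so far is the limit of > 10000 nM in this assay, at which 2 of the 2 values shown sit. Within the data shown here, the one measured step is a step that the two limits leave unreadable from compound 1 to compound 2, and it concerns phenoxy in place of chloro, so it gives no size to carry forward.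

Compound 3 `COc1ccc(/C=C/C(=O)/C=C/c2cc3ccccc3nc2Oc2ccccc2)cc1OC` differs from compound 2 by methoxy in place of hydrogen on an aromatic carbon: methoxy in place of hydrogen, turning 4-methoxyphenyl to 3,4-dimethoxyphenyl. Among the measured compounds shown here, no measured step covers this change, so no direction can be read from the data. The expectation in this assay is therefore no step beyond the scatter, and another limit is the likeliest result. The expected change is a step that the limit leaves unreadable from compound 2 to compound 3. Compound 3 is estimated at 12000 nM, with an expected range from 3000 nM to 30000 nM.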

Compound 3, half-maximal inhibitory concentration: > 10000 nM
Compound 3 gave a limit, no number (the forecaster's own chance of this, stated with the estimate: 70%); the middle value does not contradict the limit.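

Compound 3 also gives only a limit, so no new step can be read from compound 2 to compound 3, and all the compounds remain at the same limit: the limit of > 10000 nM in this assay, at which 3 of the 3 values shown sit. The compounds shown leave open what size or direction the phenoxy and methoxy changes have in this assay.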